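Notes on the benzyl para substituent in this series

This account rests on a few compounds, and the source may have more. Where it says the series, first, only, none or still open, it means among the compounds named here.

Measured so far in a functional assay on K562 cells (Homo sapiens) for antiproliferative activity, read by MTT assay, with a stated time of 48 h; a lower number here means a stronger inhibitor, a higher number a weaker inhibitor:
- compound 1 `C=CCN1C(=O)C(=O)c2cc(-c3ccc(OC)cc3)ccc21` gives 390 nM
- compound 2 `COc1ccc(-c2ccc3c(c2)C(=O)C(=O)N3Cc2ccc(Cl)cc2)cc1` gives 350 nM
- compound 3 `COc1ccc(CN2C(=O)C(=O)c3cc(-c4ccc(OC)cc4)ccc32)cc1` gives 30 nM

Compound 3 holds the lowest number of the three; its steps to the other two are both beyond the scatter, namely a 13-fold lower number from compound 1 to compound 3 (1.11 log units; beyond the scatter) and a 12-fold lower number from compound 2 to compound 3 (1.07 log units; beyond the scatter). The step of a 1.1-fold lower number from compound 1 to compound 2 (0.05 log units; within the scatter) is within the scatter.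

Compound 4 `COc1ccc(CN2C(=O)C(=O)c3cc(-c4ccc(C)cc4)ccc32)cc1` differs from compound 3 in one place: methyl in place of methoxy on an aromatic carbon. Within the data shown here, no measured pair shows methyl against methoxy at this position. Among the measured compounds shown here, the only step that touches the same aromatic carbon is a 12-fold lower number from compound 2 to compound 3 (1.07 log units; beyond the scatter), which was large, and it shows that the group at this position matters in this assay. Methyl is not chloro, so that step is only a rough guide; it suggests that removing the methoxy costs some of the gain seen in compound 3, but not necessarily all of it.

The expectation for compound 4 is therefore a moderately higher number, estimated as a 3.3-fold higher number from compound 3 to compound 4 (0.52 log units; beyond the scatter), with considerable uncertainty in both directions.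

Compound 4 is estimated at 100 nM, within a range from 30 nM to 400 nM.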

Compound 4, half-maximal inhibitory concentration: 400 nM
For compound 4 the middle estimate is 4.0-fold (0.60 log units) below the measured one, and the stated range covers the measured number.
By their numbers in this assay, from the lowest: compound 3; then compounds 2, 1 and 4 (each within the scatter of the next).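

The change in compound 4 lies in the 4-methoxyphenyl group held directly on the shared core, not on the saturated chain carbon bound to the amide-type nitrogen, where compound 2 differs from compound 3; the earlier step therefore never touched this aromatic carbon. In this assay, going from 4-methoxyphenyl to 4-methylphenyl here gives a 13-fold higher number from compound 3 to compound 4 (1.12 log units; beyond the scatter), so methyl does not keep the low number of compound 3 at this position. Together with a 12-fold lower number from compound 2 to compound 3 (1.07 log units; beyond the scatter), this shows that compound 3 loses much of its activity when either of its two methoxy groups is replaced by a single change, though each replacement has been seen with only one group. Nothing at hand gives a reason for this step.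

The compounds shown leave open whether the oxygen or the size of the group is what counts at this position, which a hydroxyl or an ethoxy group in place of the methoxy would help to separate. They also leave open how an unsubstituted phenyl or an amino group would compare with the 4-methoxyphenyl group of compound 3.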